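The compounds below may be only part of what the source reports. "The series", "measured", "known", "first", "only" and "open" are said of these compounds alone.

In a physicochemical assay for lipophilicity, at pH 7.4 (a higher number here means a more lipophilic compound, a lower number a more polar compound), compound 1 `Cc1cc(C)c(CN2CCc3ccc(O[C@@H]4CCOC4)c(Cl)c3C2=O)c(=O)[nH]1` gives 1.5 and stands lowest of the two measured compounds, with compound 2 `Cc1cc(C)c(CN2CCc3c(F)cc(O[C@@H]4CCOC4)c(Cl)c3C2=O)c(=O)[nH]1` at 2.1 above it. Moving to compound 3 `Cc1cc(C)c(CN2CCc3ccc(-c4c(C)noc4C)c(Cl)c3C2=O)c(=O)[nH]1` brings 3,5-dimethyl-1,2-oxazol-4-yl in place of (oxolan-3-yl)oxy on an aromatic carbon on the shared core. Going by the values given here, the only measured step is a number 0.60 log units higher from compound 1 to compound 2 (beyond the scatter) for a fluoro in place of hydrogen on an aromatic carbon, a different change that offers only a rough scale. The expected step of a number 0.90 log units higher from compound 1 to compound 3 (beyond the scatter) is upward in this assay and similar to or somewhat larger than that one. Compound 3 is estimated at 2.4 with an expected range from 1.8 to 3 in this measurement.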

Compound 3, distribution coefficient: 2.6
Beside the measured number, compound 3's estimate is 0.20 log units below it; low and high end bracket the measured number.
By their numbers in this assay, from the lowest: compound 1; then compound 2; then compound 3.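

On the aromatic carbon ortho to the chloro group, 3,5-dimethyl-1,2-oxazol-4-yl in place of (oxolan-3-yl)oxy gives a number 1.10 log units higher from compound 1 to compound 3 (beyond the scatter) in this assay, so this position also moves the read-out, not only the fluoro site. The step comes with equal counts of hydrogen-bond donors and acceptors in both groups, while the defined stereocentre leaves. Nothing at hand accounts for the size of this step. Still open, going by these compounds, is whether an amine or a carboxylic acid at this carbon would lower the number, and whether fluoro on compound 3 would add a similar step.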